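Swapping the imidazole arm for a thiophene

This account rests on a few compounds, and the source may have more. Where it says the series, first, only, none or still open, it means among the compounds named here.

Compounds measured in a functional assay on SK-BR-3 cells (Homo sapiens) for inhibition, read by CellTiter-Glo, with a stated time of 72 h; a higher number here means a weaker inhibitor, a lower number a stronger inhibitor:
- compound 1, `CNc1cc(-n2nc(C(C)C)c3c(-n4cnc(-c5cnn(C)c5)c4)ccnc32)ccc1C(N)=O`, 773 nM
- compound 2, `CC(C)c1nn(-c2ccc(C(N)=O)c(N[C@H]3CC[C@H](O)CC3)c2)c2nccc(-n3cnc(-c4ccc(Oc5ccccc5)cc4)c3)c12`, 503 nM
- compound 3, `CC(C)c1nn(-c2ccc(C(N)=O)c(N[C@H]3CC[C@H](O)CC3)c2)c2nccc(-n3cnc(-c4ccccc4)c3)c12`, 276 nM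

Compound 3 gives the lowest number of the three, though its gap to compound 2 lies within the scatter; only the gap to compound 1 is beyond it. Within the data shown here, the one step with a single change, a 1.8-fold lower number from compound 2 to compound 3 (0.26 log units; within the scatter), removes a phenoxy from the outer phenyl and barely moves the number. Compound 1 differs from compound 3 in two places at once, so its values show only that a smaller amine substituent together with a different imidazole substituent go with a higher number.

Compound 4, `CC(C)c1nn(-c2ccc(C(N)=O)c(N[C@H]3CC[C@H](O)CC3)c2)c2nccc(-c3ccsc3)c12`, differs from compound 3 in one place: thiophen-3-yl in place of 4-phenyl-1H-imidazol-1-yl on an aromatic carbon. No measured step touches this position, and the change is much larger than the phenoxy removal, so no expectation can rest on a shown step. Replacing the larger two-ring group by a small single ring is estimated to weaken inhibition, giving a 5.4-fold higher number from compound 3 to compound 4 (0.74 log units; beyond the scatter). Compound 4 is therefore expected to give about 1500 nM, within 400 nM to 6000 nM.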

Compound 4, half-maximal inhibitory concentration: > 10000 nM
Compound 4 ended at the assay's limit; the forecaster's own chance of this, stated with the estimate: 10%; middle value at least 6.6-fold (0.82 log units) away from the limit.
By their numbers in this assay, from the lowest: compounds 3, 2 and 1 (each within the scatter of the next, the first and the last beyond it). At a limit, above all of these: compound 4.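

In this assay compound 4 gives > 10000 nM, which is a limit of the assay and not a number. Compounds 1, 2 and 3 all carry a substituted imidazole at this aromatic carbon, opposite the ring nitrogen, so they say nothing about replacing it, whereas this change gives an at least 36-fold higher number from compound 3 to compound 4 (1.55 log units; beyond the scatter). The outer end of the group tolerated the loss of phenoxy within the scatter, but exchanging the whole 4-phenyl-1H-imidazol-1-yl group for thiophen-3-yl is a large step, the only one shown that is.

Thiophen-3-yl replaces the imidazole and its phenyl together, so the compounds shown cannot tell which of the two parts matters. A plain imidazol-1-yl or a plain phenyl on the same carbon would separate them.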